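Anilide substitution on the azo-indole series: the 2,3-dimethyl step

The source may report more compounds than this note shows. Statements on the series, on what has been measured and on what is new or still open speak of the compounds shown alone.

Compound 1, `O=C(Nc1ccccc1)c1ccc(/N=N\c2c[nH]c3ccccc23)cc1`: in a functional assay on P388 cells (Mus musculus) for inhibition, read by MTT assay, with a stated time of 72 h (a lower number here means a stronger inhibitor, a higher number a weaker inhibitor), compound 1 is reported as "not active" (no number reported), with no number given.
Compound 2, `Cc1ccc(NC(=O)c2ccc(/N=N\c3c[nH]c4ccccc34)cc2)cc1`: in this assay compound 2 gives 300 nM.
Compound 3, `Cc1cccc(NC(=O)c2ccc(/N=N\c3c[nH]c4ccccc34)cc2)c1C`: not yet measured in this assay.

Within the data shown here, compound 2 holds the only numerical reading so far; compound 1 stands beside it as an entry without a number, so no step between measured compounds can be stated, and no comparison of sizes is possible. What the two entries show is simply that the unsubstituted anilide returned nothing measurable while the 4-methylphenyl anilide returned a value.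

Compound 3 differs from compound 2 by 2,3-dimethylphenyl in place of 4-methylphenyl on an amide-type nitrogen. Among the measured compounds shown here, with no measured step available, the expectation rests on compound 2 alone, and the direction is open: the step from compound 2 to compound 3 is expected to be a 1.7-fold higher number from compound 2 to compound 3 (0.22 log units; within the scatter), which means no shift beyond the usual scatter is assumed, with a wide band to either side. Compound 3 is therefore estimated at 500 nM in this assay, within a range from 100 nM to 3000 nM.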

Compound 3, half-maximal inhibitory concentration: 51600 nM
The estimate for compound 3 lay 100-fold (2.01 log units) below the measured number; the whole stated range lies below it.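

The change from 4-methylphenyl to 2,3-dimethylphenyl on the amide-type nitrogen gives a 170-fold higher number from compound 2 to compound 3 (2.24 log units; beyond the scatter) in this assay, the first size that can be put on any change in this series, and it shows that this position does not accept every methyl-bearing phenyl group equally. Both groups are six-membered aromatic rings of carbon only, with no hydrogen-bond donors or acceptors and no net charge, and the count moves only from 7 heavy atoms to 8, so a large shift in the read-out accompanies a small change in what is counted here. Nothing measured in this set speaks to the reason for that shift.

Steps involving compound 1 cannot be read, since its entry carries no number, and the compounds shown leave open which of the two methyl groups of 2,3-dimethylphenyl goes with the loss seen for compound 3. Also open, as far as these compounds go, is how the read-out responds when the methyl of 4-methylphenyl gives way to an amine, a carboxylic acid or a longer alkyl chain.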